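Swapping 3-nitrophenyl for 3,4-dichlorophenyl on the shared core

The source may hold more compounds than are shown below. What is called first, only, known or untested is meant among the compounds shown, and "the series" means these compounds.

In a functional assay on PC-3 cells (Homo sapiens) for cytotoxicity, read by MTT assay, with a stated time of 72 h (a lower number here means a stronger inhibitor, a higher number a weaker inhibitor), compound 1 `CNC(=O)c1cc(Oc2ccc(C3=NNC(c4ccc([N+](=O)[O-])cc4)C3)cc2)ccn1` gives > 50000 nM as its result, which is a limit of the assay and not a number. Compound 2 `CNC(=O)c1cc(Oc2ccc(C3=NNC(c4cccc([N+](=O)[O-])c4)C3)cc2)ccn1` has no number to stand on, its entry being "not determined" (no result reported) in this series. Compound 3 `CNC(=O)c1cc(Oc2ccc(C3=NNC(c4ccc(Cl)c(Cl)c4)C3)cc2)ccn1` keeps the shared core and differs from compound 2 by 3,4-dichlorophenyl in place of 3-nitrophenyl on a saturated ring carbon with 3,4-dichlorophenyl in place of 3-nitrophenyl on a saturated ring carbon. Among the measured compounds shown here, no measured step exists for this change. A modest step towards a lower number is expected in this assay for this change. The estimated value for compound 3 is 25000 nM with an expected range of 7000 nM to 50000 nM as a rough guide.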

Compound 3, half-maximal inhibitory concentration: 36200 nM
Beside the measured number, compound 3's estimate is 1.4-fold (0.16 log units) below it; measured number inside the range.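

In this assay, among the compounds shown here, compound 3 gives 36200 nM, the only actual number so far for a group on this saturated ring carbon of the shared core. Placing 3,4-dichlorophenyl here in place of 4-nitrophenyl gives an at least 1.3-fold lower number from compound 1 to compound 3 (0.14 log units; that floor lies within the scatter), so no real gain can be claimed. Compound 1 has a limit and not a number: the limit of > 50000 nM in this assay, at which 1 of the 3 values shown sits.

Compound 2 has no result, and its step to compound 3 cannot be read. As far as these compounds go, whether a phenyl group carrying an amine or a carboxylic acid at this place would lower the number remains open.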